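Aryl O-methylation in a cyclic peptide series

This account rests on a few compounds, and the source may have more. Where it says the series, first, only, none or still open, it means among the compounds named here.

Measured so far:
compound 1 `COC(=O)C[C@@H]1NC(=O)[C@@H](C)NC(=O)[C@@H]2Cc3ccc(OC)c(c3)Oc3ccc(cc3)C[C@@H](C(=O)N2C)N(C)C(=O)[C@H](C)NC(=O)[C@H](Cc2ccc(OC)cc2)N(C)C1=O` gives 41.7 nM in a functional assay on P388 cells (Mus musculus) for cytotoxicity; on this read-out lower numbers stand for stronger inhibition and higher numbers for weaker inhibition;
compound 2 `COc1ccc(C[C@H]2C(=O)N[C@@H](C)C(=O)N(C)[C@H]3Cc4ccc(cc4)Oc4cc(ccc4OC)C[C@@H](C(=O)N[C@H](C)C(=O)N[C@@H](CC(=O)O)C(=O)N2C)N(C)C3=O)cc1` gives 1200 nM in this assay;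
compound 3 `C[C@@H]1NC(=O)[C@@H](C)NC(=O)[C@@H]2Cc3ccc(O)c(c3)Oc3ccc(cc3)C[C@@H](C(=O)N2C)N(C)C(=O)[C@H](C)NC(=O)[C@H](Cc2ccccc2)N(C)C1=O` gives 42.7 nM in this assay.

Compound 4 `COc1ccc2cc1Oc1ccc(cc1)C[C@H]1C(=O)N(C)[C@@H](C2)C(=O)N[C@H](C)C(=O)N[C@@H](C)C(=O)N(C)[C@@H](Cc2ccccc2)C(=O)N[C@@H](C)C(=O)N1C` is not yet measured. It differs from compound 3 by methyl in place of hydrogen on an oxygen on an aromatic ring. The same kind of change, though not the same, separates compound 2 from compound 1, namely (methyl in place of hydrogen on an oxygen next to a carbonyl group), which gave a 29-fold lower number from compound 2 to compound 1 (1.46 log units; beyond the scatter). The two places differ: one oxygen sits on an aromatic ring, the other next to a carbonyl group. The difference between the core of compound 3 and that of compound 2 is not broken down here.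

Because a 29-fold lower number from compound 2 to compound 1 (1.46 log units; beyond the scatter) arose at a different kind of oxygen, compound 4 is not expected to repeat it, and the step is estimated at a 1.1-fold lower number from compound 3 to compound 4 (0.03 log units; within the scatter). Compound 4 is estimated at 40 nM, between 15 nM and 110 nM.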

Compound 4, half-maximal inhibitory concentration: 295 nM
For compound 4 the middle estimate is 7.4-fold (0.87 log units) below the measured one; the measured number lies above the stated range.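

In this assay, the change from hydroxy to methoxy on the aromatic ring gave a 6.9-fold higher number from compound 3 to compound 4 (0.84 log units; beyond the scatter) on this core. Methylation therefore did not carry over in size or direction from the earlier step at an oxygen next to a carbonyl group: the same change on two cores in this assay, a 29-fold lower number (1.46 log units; beyond the scatter) from compound 2 to compound 1 and a 6.9-fold higher number (0.84 log units; beyond the scatter) from compound 3 to compound 4, 200-fold (2.30 log units) apart, beyond the scatter of two such steps. This does not show whether the core or the kind of oxygen sets the two steps apart, as they differ in both and no pair shown separates them.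

The compounds shown leave open how the same oxygen would respond to methylation on the other core. They also leave open whether a longer chain such as ethoxy, or an amine in place of the hydroxy, would follow methoxy on the core of compound 3.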